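This account rests on a few compounds, and the source may have more. Where it says the series, first, only, none or still open, it means among the compounds named here.

Compound 2 `CCC1C(=O)N(C)c2cnc(-n3ccc4cc(C(=O)NC)ccc43)nc2N1c1ccn(C)n1` and compound 1 `CCC1C(=O)N(C)c2cnc(-n3ccc4cc(C(=O)NC(C)C)ccc43)nc2N1c1ccn(C)n1` share one core and differ in a single place: isopropyl in place of methyl on an amide-type nitrogen. In a functional assay on K562 cells (Homo sapiens) for antiproliferative activity, read by CCK-8 assay, with a stated time of 72 h (on this read-out higher numbers stand for weaker inhibition of growth and lower numbers for stronger inhibition of growth), compound 2 gives 13300 nM and compound 1 gives 8910 nM, which amounts to a 1.5-fold lower number from compound 2 to compound 1 (0.17 log units; within the scatter). Compound 3 `CC[C@@H]1C(=O)N(C)c2cnc(-n3ccc4cc(C(=O)NC)ccc43)nc2N1C1CCCC1` carries a different core; how that core differs from the core of compound 2 is not broken down here. In this assay compound 3 gives 705 nM, the lowest of the three numbers. Compound 4 `CC[C@@H]1C(=O)N(C)c2cnc(-n3ccc4cc(C(=O)NC(C)C)ccc43)nc2N1C1CCCC1` has not yet been measured and differs from compound 3 by the same change at the same place: isopropyl in place of methyl on an amide-type nitrogen. Because the earlier step of a 1.5-fold lower number from compound 2 to compound 1 (0.17 log units; within the scatter) lay within the scatter, the corresponding step is expected to be of similar small size, a 1.3-fold lower number from compound 3 to compound 4 (0.11 log units; within the scatter). Compound 4 is therefore estimated at 550 nM in this assay, with a likely range between 250 nM and 1200 nM.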

Compound 4, concentration for 50% growth inhibition: 786 nM
Compound 4: the middle estimate sits 1.4-fold (0.16 log units) below what was measured; the measured number falls inside the stated range.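

In this assay the change from methyl to isopropyl on the amide-type nitrogen amounts to a 1.1-fold higher number from compound 3 to compound 4 (0.05 log units; within the scatter) and so stays small on the second core as well. Set side by side, the two steps do not differ: the same change on two cores in this assay, a 1.5-fold lower number (0.17 log units; within the scatter) from compound 2 to compound 1 and a 1.1-fold higher number (0.05 log units; within the scatter) from compound 3 to compound 4, 1.7-fold (0.22 log units) apart, within the scatter of two such steps. This shows that the change carried over between these two cores without a discernible shift in this read-out, but two pairs with steps this small do not show that it would behave the same way on any other core, and they do not explain why.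

The compounds shown leave open whether other groups on that nitrogen, such as cyclopropyl or a longer chain ending in an amine, would give a step beyond the scatter.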